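Benzyl in Place of Acetyl on an Aromatic Oxygen

The source may hold more compounds than are shown below. What is called first, only, known or untested is meant among the compounds shown, and "the series" means these compounds.

Measured compounds:
- compound 1, `C#CC(C)(C)Oc1ccc2ccc(=O)oc2c1`: > 20 ug/mL
- compound 2, `C=CCc1c(OC(C)=O)ccc2ccc(=O)oc12`: 0.2 ug/mL

Of the compounds shown here, two have been tested in an assay on LNCaP cells for inhibition of 3-oxo-5-alpha-steroid 4-dehydrogenase 1 (Homo sapiens); on this read-out higher numbers stand for weaker inhibition and lower numbers for stronger inhibition. Compound 1 gives only > 20 ug/mL there, which is a limit of the assay rather than a number, as noted in the limit of > 20 ug/mL in this assay, at which 1 of the 2 values shown sits. For the measured compounds named here, compound 2, by contrast, gives 0.2 ug/mL, the only actual number among the values shown. Compound 2 therefore carries the sole measured point from which an expectation can be built.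

The next compound, compound 3 with structure `C=CCc1c(OCc2ccccc2)ccc2ccc(=O)oc12`, keeps the shared core of compound 2 and differs in a single place: benzyl in place of acetyl on an oxygen on an aromatic ring. Going by the values given here, no measured pair of compounds shows what such a swap does in this assay, so the size of the step can only be guessed. The acetyl group leaves and a benzyl group enters on the same aromatic oxygen. The expectation is a small shift toward weaker inhibition, though one that may well fall within the usual scatter, so compound 3 is estimated to move by a 2.0-fold higher number from compound 2 to compound 3 (0.30 log units; within the scatter) from compound 2. On that basis compound 3 is expected to give about 0.4 ug/mL in this assay, plausibly anywhere between 0.1 ug/mL and 2 ug/mL.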

Compound 3, half-maximal inhibitory concentration: > 4 ug/mL
Compound 3 was reported as a limit (the forecaster's own chance of this, stated with the estimate: 10%); middle value at least 10-fold (1.00 log units) away from the limit.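

For the compounds shown here, the first step that can be read in this assay is large: benzyl in place of acetyl on an oxygen on an aromatic ring gives an at least 20-fold higher number from compound 2 to compound 3 (1.30 log units; beyond the scatter) and shows that inhibition depends strongly on what this oxygen carries. The rest of the two structures is the same, so this one change accounts for the whole difference between them, and an acetyl group here cannot be exchanged for benzyl without a clear loss of inhibition. Compound 3 is reported only as a limit of the assay, not as a number: the limit of > 4 ug/mL in this assay, at which 1 of the 3 values shown sits.

On these data alone, a single swap cannot separate the effect of losing acetyl from that of gaining benzyl, so it remains open how the same oxygen would behave carrying a methyl group, a longer acyl chain such as propionyl, or only a hydrogen as a free hydroxyl. Steps to compound 1 cannot be read, since it differs from the other two compounds in more than one place, and the shown compounds therefore give no hint of how the rest of the structure contributes.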